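A methylsulfonyl swap among compounds at a limit

The compounds below may be only part of what the source reports. "The series", "measured", "known", "first", "only" and "open" are said of these compounds alone.

In an ADME assay on HEK293 cells (Homo sapiens) for cytotoxicity, read by CellTiter-Glo and resazurin assay, with a stated time of 72 h (a lower number here means that less compound is needed, a higher number that more compound is needed for the effect), compound 1 (`CC(C)N(Cc1cccc(OCCCCCC(=O)O)c1)C(=O)c1ccc(-c2cccc(S(C)(=O)=O)c2)cc1`) gives > 26000 nM, which is a limit and not a number. Compound 2 (`CCOC(=O)CCCCCOc1cccc(CN(C(=O)c2ccc(-c3cccc(O)c3)cc2)C(C)C)c1`) gives > 26000 nM, again a limit. Compound 3 (`CCOC(=O)CCCCCOc1cccc(CN(C(=O)c2ccc(-c3cc(OC)ccc3F)cc2)C(C)C)c1`) gives > 26000 nM, also only a limit. Its standing is therefore shared with the other two: the limit of > 26000 nM in this assay, at which 3 of the 3 values shown sit.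

Compound 4 (`CCOC(=O)CCCCCOc1cccc(CN(C(=O)c2ccc(-c3cccc(S(C)(=O)=O)c3)cc2)C(C)C)c1`) has not yet been measured. It differs from compound 3 as follows: 3-(methylsulfonyl)phenyl in place of 2-fluoro-5-methoxyphenyl on an aromatic carbon. In words, 3-(methylsulfonyl)phenyl takes the place of 2-fluoro-5-methoxyphenyl on an aromatic carbon, para to a large group.

Among the measured compounds shown here, one measured step bears on this exchange, with 2-fluoro-5-methoxyphenyl in place of 3-hydroxyphenyl on an aromatic carbon: a step that the two limits leave unreadable from compound 2 to compound 3. It offers no size to carry over. Compound 1 already carries 3-(methylsulfonyl)phenyl and gives > 26000 nM, a limit. On this evidence, no change beyond the scatter is expected in this assay, in either direction. The estimated move is a step that the limit leaves unreadable from compound 3 to compound 4. For compound 4 the estimated value is 30000 nM, with an expected range from 15000 nM to 60000 nM, and the assay will most likely report only a limit again.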

Compound 4, half-maximal effective concentration: > 26000 nM
Compound 4 was reported as a limit (the forecaster's own chance of this, stated with the estimate: 85%); the middle value is on the limit's open side.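

Compound 4 also ends at a limit, like compounds 1, 2 and 3, so no step among these compounds can be read in this assay: the limit of > 26000 nM in this assay, at which 4 of the 4 values shown sit. The compounds shown leave open whether any of these exchanges changes the read-out at all; none of them has an actual number in this assay.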